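Swapping tert-butyl for benzyl on a shared core

A few compounds are considered here, and "the series" means these few. Any claim that something is new, unique, unknown or untested is made for them only; others in the source may bear on it.

Compound 1 `COC(C)(C)[C@@H](O)C(=O)N1C[C@H]2C[C@H]2[C@H]1C(=O)NCc1cc(Cl)ccc1-n1cnnn1`: 1000 nM
Compound 2 `O=C(NCc1cc(Cl)ccc1-n1cnnn1)[C@@H]1[C@H]2C[C@H]2CN1C(=O)[C@H](O)Cc1ccccc1`: 1200 nM
Compound 3 `CC(C)(C)[C@@H](O)C(=O)N1C[C@H]2C[C@H]2[C@H]1C(=O)NCc1cc(Cl)ccc1-n1cnnn1`: 1200 nM

All three compounds were tested in a functional assay on a cell-free system (plasma, Homo sapiens), with a stated time of 3 min (a lower number here means a stronger inhibitor, a higher number a weaker inhibitor), and their numbers lie within the scatter of one another. Compound 3 stands level with compound 2 and offers no separation from compound 1.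

The next compound is compound 4 `O=C(NCc1cc(Cl)ccc1-n1cnnn1)[C@@H]1[C@@H]2C[C@@H]2CN1C(=O)[C@H](O)Cc1ccccc1`, which follows from compound 3 by one change: benzyl in place of tert-butyl on a saturated chain carbon bound to a carbonyl carbon and an oxygen on a saturated carbon. Among the compounds with values here, only one measured step touches this part of the molecule, a 1.2-fold higher number from compound 1 to compound 3 (0.08 log units; within the scatter). Within the data shown here, it concerns a smaller edit within the tert-butyl group, so it shows only that one swap there left the number unmoved. Among the measured compounds shown here, no measured step shows benzyl in place of tert-butyl on this core. Compound 2 also carries benzyl and gives 1200 nM, but its core has a different stereochemistry, so it is only a loose guide.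

The data therefore give no firm ground for a large step in this assay. A shift within the scatter is expected, leaning slightly towards a lower number, and the estimated step is a 1.7-fold lower number from compound 3 to compound 4 (0.23 log units; within the scatter). For compound 4 the estimate is 700 nM, with an expected range from 120 nM to 3500 nM.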

Compound 4, half-maximal inhibitory concentration: 970 nM
Compound 4: middle estimate off by 1.4-fold (0.14 log units), on the low side; the measured number falls inside the stated range.
By their numbers in this assay, from the lowest: compounds 4, 1, 2 and 3 (each within the scatter of the next).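

In this assay, benzyl in place of tert-butyl on a saturated chain carbon bound to a carbonyl carbon and an oxygen on a saturated carbon gives a 1.2-fold lower number from compound 3 to compound 4 (0.09 log units; within the scatter), so this larger swap, now read directly, separates its two compounds no more than the smaller edit within the tert-butyl group did. Benzyl in place of 1-methoxy-1-methylethyl at the same place gives a 1.0-fold lower number from compound 1 to compound 4 (0.01 log units; within the scatter), which means that a group with one six-membered aromatic ring and the two ring-free groups cannot be told apart here. The third step, a 1.2-fold lower number from compound 2 to compound 4 (0.09 log units; within the scatter), isolates the drawn configuration at two saturated ring carbons, and it too stays within the scatter, which turns the earlier loose guide into a direct comparison: the fact that compounds 2 and 4 differ only in the configuration as drawn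

On these data alone, none of the four compounds carries an amine or a carboxylic acid at this position, so whether either would move the number beyond the scatter remains open. As far as these compounds go, it is also open whether a longer chain ending in a phenyl ring would behave as benzyl does, on either drawn configuration of the core.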